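The compounds below may be only part of what the source reports. "The series", "measured", "known", "first", "only" and "open" are said of these compounds alone.

Working notes on the series. Compound 1 `CN(C(=O)NC(=O)c1ccccc1F)c1nc(C(F)(F)F)c(C(=O)N/N=C/c2cc(C(F)(F)F)cc(C(F)(F)F)c2)s1` gives 5.43 ug/mL in a functional assay on A549 cells (Homo sapiens) for inhibition, read by MTT assay, with a stated time of 72 h; a higher number here means a weaker inhibitor, a lower number a stronger inhibitor. Compound 2 `CN(C(=O)NC(=O)c1ccc(F)c(F)c1)c1nc(C(F)(F)F)c(C(=O)N/N=C/c2cc(C(F)(F)F)cc(C(F)(F)F)c2)s1` gives 5.47 ug/mL in this assay, and the step of a 1.0-fold higher number from compound 1 to compound 2 (0.00 log units; within the scatter) shows nothing beyond the scatter. Compound 3 `CN(C(=O)NC(=O)c1ccc(C(F)(F)F)cc1)c1nc(C(F)(F)F)c(C(=O)N/N=C/c2cccc(C(F)(F)F)c2)s1` gives 6.66 ug/mL in this assay; this is the highest number of the three, but it lies within the scatter of compound 2 and of compound 1 alike, so no order among them is supported. Compound 4 `CN(C(=O)NC(=O)c1ccc(C(F)(F)F)cc1)c1nc(C(F)(F)F)c(C(=O)N/N=C/c2cc(C(F)(F)F)cc(C(F)(F)F)c2)s1` is not yet measured. The change is trifluoromethyl in place of hydrogen on an aromatic carbon; the rest of the molecule is that of compound 3. Going by the values given here, no measured pair differs at this site, so no step bears on it directly; the single measured step, from compound 1 to compound 2, sits elsewhere and is within the scatter. Compounds 1 and 2, which match compound 4 at the site of this change, are within the scatter of compound 3. A step of a 1.2-fold lower number from compound 3 to compound 4 (0.08 log units; within the scatter) is therefore expected, nothing beyond the scatter. Compound 4 is estimated at 5.5 ug/mL in this assay, with a range from 3.3 ug/mL to 9 ug/mL.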

Compound 4, half-maximal inhibitory concentration: 5.9 ug/mL
Beside the measured number, compound 4's estimate is 1.1-fold (0.03 log units) below it, and the stated range covers the measured number.
By their numbers in this assay, from the lowest: compounds 1, 2, 4 and 3 (each within the scatter of the next).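

Trifluoromethyl in place of hydrogen, meta to a trifluoromethyl group, now has a direct reading at this site in this assay: a 1.1-fold lower number from compound 3 to compound 4 (0.05 log units; within the scatter), so adding the group here produces no change that can be told from the scatter. With this site held fixed, the group on the carbonyl carbon can also be compared: 4-(trifluoromethyl)phenyl in place of 3,4-difluorophenyl gives a 1.1-fold higher number from compound 2 to compound 4 (0.03 log units; within the scatter), and in place of 2-fluorophenyl it gives a 1.1-fold higher number from compound 1 to compound 4 (0.04 log units; within the scatter), so these three groups do not separate. Nothing on hand accounts for how closely these numbers sit.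

As far as these compounds go, whether an amine, a carboxylic acid or a longer chain on this aromatic carbon would move the number beyond the scatter stays open. Also open, from the compounds shown here alone, is whether any change to the shared core would separate these compounds.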